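This account rests on a few compounds, and the source may have more. Where it says the series, first, only, none or still open, it means among the compounds named here.

Compound 1 `Clc1ccc(Nc2nnc(-c3ccccc3)s2)cc1Cl` was tested in an assay on isolated protein for inhibition of beta-glucuronidase (Bos taurus), read by spectrophotometry, with a stated time of 30 min (a higher number here means a weaker inhibitor, a lower number a stronger inhibitor), where compound 1 gives 6280 nM. Within the data shown here, only one other compound has been measured for comparison: compound 2 `COc1ccc(-c2nnc(Nc3ccc(Cl)c(Cl)c3)s2)cc1`, which in this assay gives 4160 nM. The shift a 1.5-fold lower number from compound 1 to compound 2 (0.18 log units; within the scatter) is small enough that the two compounds cannot be told apart, so compound 1 stands beside compound 2 rather than above or below it.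

Compound 3 `COc1ccccc1-c1nnc(Nc2ccc(Cl)c(Cl)c2)s1` is still to be measured. It differs from compound 1 by methoxy in place of hydrogen on an aromatic carbon. Among the measured compounds shown here, the only measured step that bears on this change is the one from compound 1 to compound 2, which is also a methoxy entering on an aromatic carbon and was a 1.5-fold lower number from compound 1 to compound 2 (0.18 log units; within the scatter). On that evidence no shift beyond the scatter is expected, so the estimated step of a 1.1-fold lower number from compound 1 to compound 3 (0.06 log units; within the scatter) is small. Compound 3 is therefore expected to give about 5500 nM, within a range of 2000 nM to 15000 nM.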

Compound 3, half-maximal inhibitory concentration: 22600 nM
Beside the measured number, compound 3's estimate is 4.1-fold (0.61 log units) below it, and the stated range ends below it.
By their numbers in this assay, from the lowest: compounds 2 and 1 (each within the scatter of the next); then compound 3.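

In this assay methoxy in place of hydrogen is not always a harmless change: ortho to a large group it gives a 3.6-fold higher number from compound 1 to compound 3 (0.56 log units; beyond the scatter) and so a weaker inhibitor than compound 1. The same group placed differently gave only a 1.5-fold lower number from compound 1 to compound 2 (0.18 log units; within the scatter) and so the effect of methoxy on this ring depends on where it sits, which the earlier pair alone could not reveal. Nothing measured here explains the weaker inhibition.

On these data alone, whether a fluorine, a hydroxyl or a longer chain such as ethoxy at this same place would also weaken inhibition remains open. It is therefore unclear whether this result is particular to methoxy or would follow from any group placed there.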